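Swapping Chloro for Amino on a Two-Ring Core

The source may hold more compounds than are shown below. What is called first, only, known or untested is meant among the compounds shown, and "the series" means these compounds.

Four compounds share a two-ring core carrying a benzyl arm that bears a chloromethyl group: compound 1 `Nc1nc(Cl)c2ncn(Cc3ccc(CCl)cc3)c2n1`, compound 2 `ClCc1cccc(Cn2cnc3c(Cl)nc(Cl)nc32)c1`, compound 3 `ClCc1ccc(Cn2cnc3c(Cl)nc(Cl)nc32)cc1` and the still unmeasured compound 4 `Nc1nc(Cl)c2ncn(Cc3cccc(CCl)c3)c2n1`. Growth inhibition was measured in a functional assay on OVCAR-5 cells (Homo sapiens) for cytotoxicity, read by sulforhodamine B assay, with a stated time of 48 h; on this read-out higher numbers stand for weaker inhibition of growth and lower numbers for stronger inhibition of growth. In this assay compound 1 gives 3310 nM, compound 2 gives 6450 nM, and compound 3 gives 18200 nM.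

Compound 1 and compound 3 differ in one place: amino in place of chloro on an aromatic carbon. This change gave a 5.5-fold lower number from compound 3 to compound 1 (0.74 log units; beyond the scatter). Compound 2 and compound 3 are built from the same atoms joined differently, and the difference between their two cores is not broken down here. Compound 4 relates to compound 2 by the same change: amino in place of chloro on an aromatic carbon. The surroundings of the changed carbon are described in the same words for both pairs, so the change is the same.

Because of a 5.5-fold lower number from compound 3 to compound 1 (0.74 log units; beyond the scatter), a step of comparable size is expected from compound 2 to compound 4 in this assay, namely a 4.6-fold lower number from compound 2 to compound 4 (0.66 log units; beyond the scatter). This rests on a single earlier example, so some caution applies. Compound 4 is therefore expected to give 1400 nM, most likely between 500 nM and 4000 nM.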

Compound 4, concentration for 50% growth inhibition: 11000 nM
Compound 4: the middle estimate sits 7.9-fold (0.90 log units) below what was measured; measured number outside the range, above it.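

In this assay, amino in place of chloro on an aromatic carbon gave a 1.7-fold higher number from compound 2 to compound 4 (0.23 log units; within the scatter), so the clear drop seen on the other core did not appear here. Set side by side, the two results disagree, which shows that the step measured on one core could not simply be carried over to the other in this series: the same change on two cores in this assay, a 5.5-fold lower number (0.74 log units; beyond the scatter) from compound 3 to compound 1 and a 1.7-fold higher number (0.23 log units; within the scatter) from compound 2 to compound 4, 9.4-fold (0.97 log units) apart, beyond the scatter of two such steps. With only these two pairs, the data do not show which part of the difference between the two cores, built from the same atoms joined differently, goes with this disagreement, or whether it would hold in any other cell line.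

The compounds shown leave open how a different group on the same carbon between two ring nitrogen atoms, such as a methylamino or a methoxy group, would fare on each core. They also leave open what would happen if a plain methyl group took the place of the chloromethyl group on the benzyl arm.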